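Swapping one phenyl group: expectations for compound 3

The source may hold more compounds than are shown below. What is called first, only, known or untested is meant among the compounds shown, and "the series" means these compounds.

- compound 1 `CC1(C)[C@H]2CC[C@]1(C)N(Cc1cn(-c3cccc(Cl)c3)nn1)C(=O)C2` gives 60 nM in the test below
- compound 2 `Cc1ccccc1-n1cc(CN2C(=O)C[C@@H]3CC[C@@]2(C)C3(C)C)nn1` gives 90 nM in the same test

Among the compounds with values here, both values come from a functional assay on A549 cells (Homo sapiens) for inhibition, read by MTT assay, with a stated time of 24 h (a lower number here means a stronger inhibitor, a higher number a weaker inhibitor), and no other compound has been measured there so far. Within the data shown here, compound 2 cannot be told apart from compound 1, its only neighbour on this scale, since the two differ by no more than the usual scatter.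

Compound 3 `CC1(C)[C@H]2CC[C@]1(C)N(Cc1cn(-c3cccc(Br)c3)nn1)C(=O)C2` has not been measured. It keeps the shared core and changes one group (3-bromophenyl in place of 2-methylphenyl on an aromatic nitrogen), with 3-bromophenyl in place of 2-methylphenyl on an aromatic nitrogen.

Among the measured compounds shown here, only one measured step changes a group at that same place. That step, a 1.5-fold higher number from compound 1 to compound 2 (0.18 log units; within the scatter), is small, so no step beyond the scatter is expected in this assay for this change. The estimated step is a 1.5-fold lower number from compound 2 to compound 3 (0.18 log units; within the scatter) and would also be too small to read as a real difference. For compound 3 the expected value is 60 nM, with an estimated range from 25 nM to 140 nM for repeated measurements.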

Compound 3, half-maximal inhibitory concentration: 90 nM
For compound 3 the middle estimate is 1.5-fold (0.18 log units) below the measured one, within the range that was stated.
By their numbers in this assay, from the lowest: compounds 1, 2 and 3 (each within the scatter of the next).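

In this assay, 3-bromophenyl in place of 2-methylphenyl on the aromatic nitrogen gives no change at the digits printed from compound 2 to compound 3 (within the scatter), and bromo in place of chloro on an aromatic carbon gives a 1.5-fold higher number from compound 1 to compound 3 (0.18 log units; within the scatter). The earlier compounds offered only one swap at this place, whereas there are now two further comparisons, including one that changes only the halogen, and neither can be told apart from the scatter, so the three phenyl groups shown give values that read as the same in this test. No supporting evidence is available to explain why these values stay so close.

From the compounds shown here alone, all three compounds carry a phenyl ring with one small group on it, so it remains open whether a phenyl ring bearing an amine or a carboxylic acid would produce a step beyond the scatter. Going by these compounds, it also remains open whether the value would hold if a longer chain, such as butyl, replaced the whole phenyl ring on that nitrogen.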